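A few compounds are considered here, and "the series" means these few. Any claim that something is new, unique, unknown or untested is made for them only; others in the source may bear on it.

In a functional assay on MCF7 cells (Homo sapiens) for antiproliferative activity, read by MTT assay, with a stated time of 48 h (a higher number here means a weaker inhibitor, a lower number a stronger inhibitor), three compounds built on one shared core have been measured. Compound 1 `O=C(/C=C/c1ccc(O)c(O)c1)N1CCN(c2ccc(F)cc2)CC1` gives 1.44 ug/mL, compound 2 `COc1cccc(N2CCN(C(=O)/C=C/c3ccc(O)c(O)c3)CC2)c1` gives 0.92 ug/mL, and compound 3 `O=C(/C=C/c1ccc(O)c(O)c1)N1CCN(c2ccc([N+](=O)[O-])cc2)CC1` gives 1.14 ug/mL. Compound 3 therefore sits in one tight group with the other two, and the numbers cannot separate it from either: the data show a 1.3-fold lower number from compound 1 to compound 3 (0.10 log units; within the scatter) and a 1.2-fold higher number from compound 2 to compound 3 (0.09 log units; within the scatter).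

Compound 4 `O=C(/C=C/c1ccc(O)c(O)c1)N1CCN(c2ccc(Cl)c(Cl)c2)CC1` has 3,4-dichlorophenyl in place of 4-nitrophenyl on an amine nitrogen in a ring. The measured steps that bear on this are the swaps at that same nitrogen. Besides the two above, there is a 1.6-fold lower number from compound 1 to compound 2 (0.19 log units; within the scatter). None of these three compounds carries chlorine, so the range must stay wide. Still, with every swap so far as small as a 1.6-fold lower number from compound 1 to compound 2 (0.19 log units; within the scatter) or less, no step beyond the scatter is expected in this assay. The expected step is a 1.0-fold lower number from compound 3 to compound 4 (0.02 log units; within the scatter). For compound 4 the estimated value is 1.1 ug/mL, with an expected range from 0.55 ug/mL to 2.4 ug/mL.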

Compound 4, half-maximal inhibitory concentration: 1.28 ug/mL
Beside the measured number, compound 4's estimate is 1.2-fold (0.07 log units) below it, and the stated range covers the measured number.
By their numbers in this assay, from the lowest: compounds 2, 3, 4 and 1 (each within the scatter of the next).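

Chlorine appears on the aromatic ring at this nitrogen for the first time with compound 4, yet in this assay the 3,4-dichlorophenyl group cannot be separated from the other groups: there is a 1.1-fold higher number from compound 3 to compound 4 (0.05 log units; within the scatter) and a 1.4-fold higher number from compound 2 to compound 4 (0.14 log units; within the scatter) and also a 1.1-fold lower number from compound 1 to compound 4 (0.05 log units; within the scatter) in this set. The 4-fluorophenyl, 3-methoxyphenyl, 4-nitrophenyl and 3,4-dichlorophenyl compounds therefore form one tight group, with every swap shown at this position staying within the scatter. Nothing measured here offers a reason for this sameness.

As far as these compounds go, all four groups are substituted phenyl rings, so it remains open whether a cyclohexyl ring or a methyl group on this nitrogen, or a phenyl ring carrying an amine or a carboxylic acid, would stay in the same group. From the compounds shown here alone, whether the four compounds also stay together on other cell lines remains open too.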